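The source may hold more compounds than are shown below. What is called first, only, known or untested is meant among the compounds shown, and "the series" means these compounds.

Among the measured compounds shown here, compound 1 `CCCCCCNc1nc(=O)n([C@H]2C[C@H](O)[C@@H](CO)O2)cc1C` is one of only two compounds tested so far in an ADME assay on A549 cells (Homo sapiens) for cytotoxicity, read by MTT assay; on this read-out lower numbers stand for higher toxicity in this test and higher numbers for lower toxicity in this test. In this test compound 1 gives 90000 nM, and compound 2 `O=c1nc(NCCCCc2ccccc2)ccn1[C@H]1C[C@H](O)[C@@H](CO)O1` gives 90000 nM, so the two stand level, within the scatter. For the measured compounds named here, no step between measured compounds is available to show how far a change of this kind can move the read-out.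

Compound 3 `COCCOCCOCCNc1nc(=O)n([C@H]2C[C@H](O)[C@@H](CO)O2)cc1C` has not yet been measured. It keeps the core of compound 1 but carries 2-(2-methoxyethoxy)ethoxy in place of butyl, on a saturated chain carbon, two bonds along the chain from a nitrogen on an aromatic ring (2-(2-methoxyethoxy)ethoxy in place of butyl on a saturated chain carbon, two bonds along the chain from a nitrogen on an aromatic ring).

The only anchors are the two level values, with compound 1 at 90000 nM as the direct starting point. A modest move towards higher numbers in this assay is expected, meaning lower toxicity in this test, and it may not clear the scatter by much. The expected change is a 1.7-fold higher number from compound 1 to compound 3 (0.22 log units; within the scatter). For compound 3 the estimated value is 150000 nM, with an expected range from 80000 nM to 400000 nM.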

Compound 3, half-maximal cytotoxic concentration: 90000 nM
The estimate for compound 3 lay 1.7-fold (0.22 log units) above the measured number; low and high end bracket the measured number.
By their numbers in this assay, from the lowest: compounds 1, 2 and 3 (each within the scatter of the next).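

In this assay, putting 2-(2-methoxyethoxy)ethoxy in place of butyl on a saturated chain carbon, two bonds along the chain from a nitrogen on an aromatic ring, gives no change at the digits printed from compound 1 to compound 3 (within the scatter). Among the compounds shown here, this is the first step that can be read at this position, and it shows that a chain of 8 heavy atoms, 3 of them oxygen and all 3 counted as hydrogen-bond acceptors, can take the place of an all-carbon butyl of 4 heavy atoms without the read-out leaving the scatter. Nothing at hand offers an explanation for this result.

The compounds shown leave open whether an amine or a carboxylic acid at the end of this chain, or a longer chain, or a phenyl ring on it in the presence of the same core, would shift the number beyond the scatter. With this single step, they also leave open whether the same exchange would give the same outcome on a different core or in a different cell line.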